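A few compounds are considered here, and "the series" means these few. Any claim that something is new, unique, unknown or untested is made for them only; others in the source may bear on it.

Compound 1 `CCOC(=O)c1cnc(SC)nc1NN1C(=O)C=C(C)C1=O` and compound 2 `CCOC(=O)c1cnc(-c2cccc(Br)c2)nc1NN1C(=O)C=C(C)C1=O` share one core and differ at a single aromatic carbon, where compound 1 carries methylsulfanyl and compound 2 carries 3-bromophenyl. Going by the values given here, in a functional assay on Jurkat cells for inhibition of nuclear factor NF-kappa-B complex (Homo sapiens) (a higher number here means a weaker inhibitor, a lower number a stronger inhibitor), compound 1 gives 200 nM, and compound 2 gives 700 nM, the highest of the two numbers so far; the step between them is a 3.5-fold higher number from compound 1 to compound 2 (0.54 log units; beyond the scatter). Compound 3 `CCOC(=O)c1cnc(Sc2ccccc2)nc1NN1C(=O)C=C(C)C1=O` has not yet been measured. It differs from compound 2 as follows: phenylsulfanyl in place of 3-bromophenyl on an aromatic carbon. Among the compounds with values here, the only measured step that bears on this change is a 3.5-fold higher number from compound 1 to compound 2 (0.54 log units; beyond the scatter), in which methylsulfanyl gave way to 3-bromophenyl and the number rose modestly. Compound 3 restores a sulfur at that carbon while keeping an aromatic ring, so the expected step is a 1.8-fold lower number from compound 2 to compound 3 (0.24 log units; within the scatter), a move back towards the number of compound 1 without fully reaching it. The estimate for compound 3 in this assay is 400 nM, with an expected range from 150 nM to 1200 nM.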

Compound 3, half-maximal inhibitory concentration: 1000 nM
For compound 3 the middle estimate is 2.5-fold (0.40 log units) below the measured one; the measured number falls inside the stated range.
By their numbers in this assay, from the lowest: compound 1; then compounds 2 and 3 (each within the scatter of the next).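

In this assay, phenylsulfanyl in place of 3-bromophenyl gives a 1.4-fold higher number from compound 2 to compound 3 (0.15 log units; within the scatter), so a sulfur link to the aromatic ring does not set these two compounds apart, and the change of bromine-bearing ring for unsubstituted ring cannot be read separately from it. Keeping the sulfur and exchanging only what it carries isolates a further comparison: phenyl in place of methyl on the sulfur gives a 5.0-fold higher number from compound 1 to compound 3 (0.70 log units; beyond the scatter), a step that compound 2 alone could not provide, as it differs from compound 1 in both the sulfur and the ring. Across these three compounds, then, compound 1 with its methylsulfanyl group has the lowest number, and both compounds with an aromatic ring at this carbon, directly attached or through sulfur, stand beyond the scatter from it, though nothing available gives a reason for this.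

An ethyl group or a longer chain on the sulfur would show whether the number climbs gradually from methyl towards phenyl, and an amine at the same carbon would test whether the sulfur is needed at all. Going by these compounds, how far the ethoxycarbonyl group contributes also stays open, and a carboxylic acid in its place would address that.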